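The source may report more compounds than this note shows. Statements on the series, on what has been measured and on what is new or still open speak of the compounds shown alone.

Working notes on the series

Three analogues of one shared core have been run in a functional assay on MCF7 cells (Homo sapiens) for cytotoxicity, read by MTT assay; on this read-out higher numbers stand for weaker inhibition and lower numbers for stronger inhibition. Compound 1 `COc1cccc(/C=C2\CCC/C(=C\c3ccccc3[N+](=O)[O-])C2=O)c1` gives 5.62 ug/mL. Compound 2 `COc1cccc(/C=C2\CCC/C(=C\c3cccc([N+](=O)[O-])c3)C2=O)c1OC`, which carries two methoxy groups on its left-hand aromatic ring, gives 5.14 ug/mL. Compound 3 `COc1cccc(/C=C2\CCC/C(=C\c3ccc([N+](=O)[O-])cc3)C2=O)c1` gives 5.82 ug/mL. The three numbers sit close together: the gap from compound 3 to compound 1 and the gap from compound 3 to compound 2 are both within the scatter of repeated measurements, so no order can be read among them in this assay.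

Compound 4 `COc1cccc(/C=C2\CCC/C(=C\c3ccc([N+](=O)[O-])cc3)C2=O)c1OC` has not yet been measured. It differs from compound 3 by a single change: methoxy in place of hydrogen on an aromatic carbon. The same kind of addition distinguishes compound 2 from compound 1, although the nitro group sits differently in that pair, and compound 2 at 5.14 ug/mL stands within the scatter of compound 1 at 5.62 ug/mL.

On that basis no step beyond the scatter is expected in this assay, in either direction. Compound 4 is estimated at 5.3 ug/mL, with a range from 3 ug/mL to 9.5 ug/mL. The step this estimate implies, a 1.1-fold lower number from compound 3 to compound 4 (0.04 log units; within the scatter), is expected to stay within the usual scatter.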

Compound 4, half-maximal inhibitory concentration: 13.3 ug/mL
Compound 4: the middle estimate sits 2.5-fold (0.40 log units) below what was measured; the whole stated range lies below it.
By their numbers in this assay, from the lowest: compounds 2, 1 and 3 (each within the scatter of the next); then compound 4.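

In this assay, methoxy in place of hydrogen on an aromatic carbon, ortho to a large group and ortho to a methoxy group, does not leave the number unchanged in the 4-nitrophenyl setting: the addition gives a 2.3-fold higher number from compound 3 to compound 4 (0.36 log units; beyond the scatter), a modest move toward weaker inhibition. With this second methoxy group in place, the nitro arrangement also registers, as 4-nitrophenyl in place of 3-nitrophenyl gives a 2.6-fold higher number from compound 2 to compound 4 (0.41 log units; beyond the scatter), again modest, whereas the earlier three numbers could not be ordered. Nothing at hand accounts for either step, so both stand as observations only.

The compounds shown do not tell whether the step at this carbon belongs to methoxy specifically or would follow from other groups there, such as a hydroxyl, an ethoxy or a fluorine atom. Nor do they isolate the effect of this same addition with the nitro group placed differently, so the step from compound 3 to compound 4 cannot yet be taken as general across the series.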